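From cyclopentylamino to allyloxy: expected tolerance in cells

The compounds below may be only part of what the source reports. "The series", "measured", "known", "first", "only" and "open" are said of these compounds alone.

Of the compounds shown here, three have been tested in an ADME assay on BCBL1 cells (Homo sapiens) for cytotoxicity, with a stated time of 7 days; a higher number here means that more compound is tolerated, a lower number that less compound is tolerated. Among the compounds with values here, compound 3 `Nc1nc(NC2CCCC2)c2ncn(/C=C3/CC3(CO)CO)c2n1` gives 71700 nM, the only number among the three. For compound 1 `Nc1nc(NC2CCCCC2)c2ncn(/C=C3/CC3(CO)CO)c2n1` the assay reports just a limit, > 20000 nM. For compound 2 `CCCOc1nc(N)nc2c1ncn2/C=C1/CC1(CO)CO` the assay likewise reports just a limit, > 20000 nM. Compound 4 `C=CCOc1nc(N)nc2c1ncn2/C=C1/CC1(CO)CO` has not yet been measured. It differs from compound 3 in one place: allyloxy in place of cyclopentylamino on an aromatic carbon The step that the limit leaves unreadable from compound 2 to compound 3 bears most on this change, trading propoxy for cyclopentylamino, but the limit of > 20000 nM in this assay, at which 2 of the 3 values shown sit, leaves its size unreadable; the same holds for a step that the limit leaves unreadable from compound 1 to compound 3 and a step that the two limits leave unreadable from compound 1 to compound 2. No shown step fixes the size of the expected step of a 1.4-fold lower number from compound 3 to compound 4 (0.16 log units; within the scatter), so no change beyond the scatter is expected. Compound 4 is therefore estimated at 50000 nM, with a likely range from 20000 nM to 150000 nM.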

Compound 4, half-maximal cytotoxic concentration: > 20000 nM
Compound 4 ended at the assay's limit; the forecaster's own chance of this, stated with the estimate: 55%; the middle value is on the limit's open side.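

Compound 4 gives only a limit in this assay, so no new step can be read between it and compound 1, compound 2 or compound 3: the limit of > 20000 nM in this assay, at which 3 of the 4 values shown sit. Going by these compounds, whether compound 1, compound 2 and compound 4 truly differ from compound 3, or from one another, stays open.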